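A few compounds are considered here, and "the series" means these few. Any claim that something is new, unique, unknown or untested is made for them only; others in the source may bear on it.

Two compounds share one core and differ only in the group attached to it. Compound 1 `CC(c1c(F)cc2ncccc2c1F)n1cnc2ncc(-c3cnn(CCO)c3)nc21` carries a 1-(2-hydroxyethyl)-1H-pyrazol-4-yl group and, in an ADME assay on microsomes from liver (Homo sapiens) for metabolic stability, read by LC-MS, using NADPH, with stated times of 5 min and 30 min, tested at 1 uM (on this read-out lower numbers stand for slow clearance and higher numbers for fast clearance), compound 1 gives 2 uL/min. Within the data shown here, compound 2 `COC(=O)c1ccc(-c2cnc3ncn(C(C)c4c(F)cc5ncccc5c4F)c3n2)cc1F` carries a 3-fluoro-4-(methoxycarbonyl)phenyl group instead, and in this assay compound 2 gives 290 uL/min, the higher of the two numbers measured; the single known step is a 150-fold higher number from compound 1 to compound 2 (2.16 log units; beyond the scatter). Compound 3 `CC(c1c(F)cc2ncccc2c1F)n1cnc2ncc(-c3cnc4ccccc4c3)nc21` changes the same position again: quinolin-3-yl in place of 3-fluoro-4-(methoxycarbonyl)phenyl on an aromatic carbon. Among the measured compounds shown here, that one step is the only guide, and it shows that swapping the group at this position can move the read-out a great deal. For the measured compounds named here, with no second step to narrow the direction, the expectation is drawn toward the middle of the known span, so for compound 3 the expected step in this assay is a 4.8-fold lower number from compound 2 to compound 3 (0.68 log units; beyond the scatter). The estimate for compound 3 is 60 uL/min, with a range from 12 uL/min to 250 uL/min.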

Compound 3, intrinsic clearance in a liver preparation (reported as CLH), per the amount of preparation that the assay uses: 51 uL/min
Beside the measured number, compound 3's estimate is 1.2-fold (0.07 log units) above it; the range from low to high includes it.
By their numbers in this assay, from the lowest: compound 1; then compound 3; then compound 2.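

In this assay, quinolin-3-yl falls inside the span set by the two earlier groups: replacing 3-fluoro-4-(methoxycarbonyl)phenyl gives a 5.7-fold lower number from compound 2 to compound 3 (0.75 log units; beyond the scatter), while replacing 1-(2-hydroxyethyl)-1H-pyrazol-4-yl gives a 26-fold higher number from compound 1 to compound 3 (1.41 log units; beyond the scatter). Three groups at this one position now give three numbers clearly apart, so the read-out here is not limited to two extremes, and a group with two aromatic rings can sit in the middle of the range. Nothing shown here explains this order.

The compounds shown leave open which part of each group sets the number, as the ester of compound 2 and the hydroxyethyl chain of compound 1 each come with a different ring. A carboxylic acid in place of the methyl ester, or a longer chain on the pyrazole, would test each part alone.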